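A few compounds are considered here, and "the series" means these few. Any claim that something is new, unique, unknown or untested is made for them only; others in the source may bear on it.

Series notes, a physicochemical assay for solubility, read by HPLC; a lower number here means a less soluble compound, a higher number a more soluble compound. Of the compounds shown here, three of the shared core have been measured. Compound 1 `CCC(=O)N1CCN(c2nc(=O)c3cc(C(F)(F)F)cc([N+](=O)[O-])c3s2)CC1` gives 3.29 ug/mL. Compound 2 `CSCC(=O)N1CCN(c2nc(=O)c3cc(C(F)(F)F)cc([N+](=O)[O-])c3s2)CC1` gives 15.2 ug/mL, and compound 3 `Cc1ccc(C(=O)N2CCN(c3nc(=O)c4cc(C(F)(F)F)cc([N+](=O)[O-])c4s3)CC2)cc1` gives 6.7 ug/mL. Among these three numbers compound 3 stands second highest: the step of a 2.0-fold higher number from compound 1 to compound 3 (0.31 log units; beyond the scatter) sets it apart from compound 1, and a 2.3-fold lower number from compound 2 to compound 3 (0.36 log units; beyond the scatter) sets it apart from compound 2, while the remaining step, a 4.6-fold higher number from compound 1 to compound 2 (0.66 log units; beyond the scatter), joins the two chain amides.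

Compound 4 `CC(=O)N1CCN(c2nc(=O)c3cc(C(F)(F)F)cc([N+](=O)[O-])c3s2)CC1` is not yet measured in this assay. Its difference from compound 3 is methyl in place of 4-methylphenyl on a carbonyl carbon, the change sitting on a carbonyl carbon whose other neighbour is an amide-type nitrogen in a ring. Going by the values given here, the only measured step that bears on this is a 2.0-fold higher number from compound 1 to compound 3 (0.31 log units; beyond the scatter), which runs the opposite way, ethyl to 4-methylphenyl. Among the compounds with values here, compound 4 differs from compound 1 only by methyl in place of ethyl, a change with no measured counterpart. Reversing the 4-methylphenyl-for-chain change is therefore expected to give a modest fall in this assay, a 1.9-fold lower number from compound 3 to compound 4 (0.28 log units; within the scatter), bringing compound 4 close to compound 1. Compound 4 is estimated at 3.5 ug/mL, within a range of 1.5 ug/mL to 8 ug/mL.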

Compound 4, solubility: 83.9 ug/mL
For compound 4 the middle estimate is 24-fold (1.38 log units) below the measured one; measured number above the stated range.
By their numbers in this assay, from the lowest: compound 1; then compound 3; then compound 2; then compound 4.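

In this assay this position does not follow the earlier small steps: hydrogen in place of methyl on a saturated chain carbon bound to a carbonyl carbon gives a 26-fold higher number from compound 1 to compound 4 (1.41 log units; beyond the scatter) and exceeds every step among compounds 1, 2 and 3, so a change of a single methyl here can carry a large effect. The acetyl group of compound 4 also stands clear of the other two groups, with a 5.5-fold higher number from compound 2 to compound 4 (0.74 log units; beyond the scatter) for hydrogen in place of methylsulfanyl at that same chain carbon and a 13-fold higher number from compound 3 to compound 4 (1.10 log units; beyond the scatter) for methyl in place of 4-methylphenyl on the carbonyl carbon, and the number therefore does not rise or fall steadily with the size of the group across these four compounds. No measurement in hand accounts for the jump.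

The compounds shown leave open whether the high number belongs to acetyl alone or extends to other small groups on this carbonyl carbon, such as cyclopropyl or methoxymethyl. They also leave open how a chain ending in an amine or a carboxylic acid would compare with acetyl on the same core.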